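The source may report more compounds than this note shows. Statements on the series, on what has been measured and on what is new or still open speak of the compounds shown alone.

Measured so far in an ADME assay on microsomes from liver (Homo sapiens) for metabolic stability; on this read-out lower numbers stand for slow clearance and higher numbers for fast clearance:
- compound 1, `Cc1cc2c(cc1Cc1ccc(-n3cccn3)cc1)C(=O)N([C@H]1CCOC[C@@H]1O)C2`: < 8 mL/min/kg
- compound 2, `Cc1cc2c(cc1Cc1ccc(-c3cscn3)cc1)C(=O)N([C@H]1CCOC[C@@H]1O)C2`: 10 mL/min/kg
- compound 3, `Cc1cc2c(cc1Cc1ccc(-c3cnn(C)c3)cc1)C(=O)N([C@H]1CCOC[C@@H]1O)C2`: 15 mL/min/kg

The value of compound 1 is a limit of this assay, not a number. Of the two numbers shown, compound 2 stands at the lowest; its nearest neighbour is compound 3, with a 1.5-fold higher number from compound 2 to compound 3 (0.18 log units; within the scatter), a gap that is within the scatter.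

Compound 4 is `Cc1cn(-c2ccc(Cc3cc4c(cc3C)CN([C@H]3CCOC[C@@H]3O)C4=O)cc2)cn1`; it is not yet measured. It differs from compound 2 in one place: 4-methyl-1H-imidazol-1-yl in place of 1,3-thiazol-4-yl on an aromatic carbon.

Among the compounds with values here, two measured steps touch the same position. From compound 1 to compound 2, an at least 1.2-fold higher number from compound 1 to compound 2 (0.09 log units; that floor lies within the scatter); from compound 1 to compound 3, an at least 1.8-fold higher number from compound 1 to compound 3 (0.27 log units; that floor lies within the scatter). Both rest on the limit of compound 1, (the limit of < 8 mL/min/kg in this assay, at which 1 of the 3 values shown sits), so their true size is not fixed, only a floor that lies within the scatter. From compound 2 to compound 3, a 1.5-fold higher number from compound 2 to compound 3 (0.18 log units; within the scatter), also within the scatter. The three azoles thus keep this assay within a narrow band, and no step beyond the scatter is expected for compound 4 either.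

The estimate for compound 4 is 8 mL/min/kg, with a range from 4 mL/min/kg to 16 mL/min/kg, which would mean an expected 1.3-fold lower number from compound 2 to compound 4 (0.10 log units; within the scatter).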

Compound 4, clearance: 30 mL/min/kg
Compound 4: middle estimate off by 3.8-fold (0.57 log units), on the low side, and the stated range ends below it.
By their numbers in this assay, from the lowest: compounds 2, 3 and 4 (each within the scatter of the next, the first and the last beyond it). At a limit, below all of these: compound 1.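

In this assay, within the data shown here, the steps among the three earlier azoles could not be told from the scatter or rested on a limit, whereas 4-methyl-1H-imidazol-1-yl in place of 1,3-thiazol-4-yl gives the first step between two numbers that lies beyond it: a 3.0-fold higher number from compound 2 to compound 4 (0.48 log units; beyond the scatter). The change of azole at this position can therefore move the clearance read-out, but the new group does not stand apart from every earlier one, as the step from the 1-methyl-1H-pyrazol-4-yl group remains inside the scatter: a 2.0-fold higher number from compound 3 to compound 4 (0.30 log units; within the scatter). The value of compound 1 is a limit, not a number, so the step that starts from it, an at least 3.7-fold higher number from compound 1 to compound 4 (0.57 log units; beyond the scatter), gives only a floor, though that floor already lies beyond the scatter: the limit of < 8 mL/min/kg in this assay, at which 1 of the 4 values shown sits.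

As far as these compounds go, it remains open whether the higher number belongs to the imidazole ring or to its methyl group, a question that a plain 1H-imidazol-1-yl group would address. Also open, from the compounds shown here alone, is how this assay would read with a group other than a five-membered aromatic ring at this position, such as a nitrile or a morpholine.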